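The compounds below may be only part of what the source reports. "The series", "measured", "known", "first", "only" and "open" are said of these compounds alone.

Working notes on the series. Of the compounds shown here, three have been read in an ADME assay on HEK293 cells (Homo sapiens) for cytotoxicity, with a stated time of 72 h; a higher number here means that more compound is needed for the effect, a lower number that less compound is needed. Compound 1 `Cc1cc(NC(=O)Nc2ccccc2OC(F)(F)F)c2ccccc2n1` gives > 25000 nM, which is a limit of the assay and not a number. Compound 3 `Cc1cc(NC(=O)Nc2cccc(C(N)=O)c2)c2ccccc2n1` gives > 25000 nM, again only a limit. Among the measured compounds shown here, compound 2 `CSc1ccc(NC(=O)Nc2cc(C)nc3ccccc23)cc1` gives 24000 nM, the only actual number among the three. The other two values coincide at one ceiling: the limit of > 25000 nM in this assay, at which 2 of the 3 values shown sit. For the measured compounds named here, no measured step therefore exists, and compound 2 cannot be ranked against compound 1 or compound 3.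

Compound 4 `Cc1cc(NC(=O)Nc2ccc(F)cc2)c2ccccc2n1` has yet to be measured in this assay. Relative to compound 2, it carries fluoro in place of methylsulfanyl on an aromatic carbon of a six-membered aromatic ring of carbon only, para to a large group (fluoro in place of methylsulfanyl on an aromatic carbon). The expected step is a 1.1-fold higher number from compound 2 to compound 4 (0.03 log units; within the scatter), with no change beyond the usual scatter in either direction. This expectation rests on compound 2 at 24000 nM, the only numerical anchor available. There is a substantial expected chance that compound 4 returns only a limit. The estimate for compound 4 is 26000 nM, with an expected range from 13000 nM to 50000 nM.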

Compound 4, half-maximal effective concentration: > 25000 nM
Compound 4 ended at the assay's limit; the forecaster's own chance of this, stated with the estimate: 65%; the middle value lies beyond the limit too.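

In this assay, among the compounds shown here, replacing methylsulfanyl with fluoro on an aromatic carbon para to a large group gives the only step that can be read, and it has a floor but no upper bound: an at least 1.0-fold higher number from compound 2 to compound 4 (0.01 log units; that floor lies within the scatter). Compound 4 gives > 25000 nM, which is a limit of the assay and not a number. The one numerical value in the series, that of compound 2, therefore cannot be shown to depend on methylsulfanyl at this position, and the true size of the step remains unknown because the reading stops at the ceiling: the limit of > 25000 nM in this assay, at which 3 of the 4 values shown sit.

All other steps among these compounds cannot be read, so it remains open whether any group at this position can bring the number clearly below the ceiling. Also open, on these data alone, is what this assay would give with an amine or a carboxylic acid on the same aromatic carbon, or with a longer chain such as ethylsulfanyl in place of methylsulfanyl.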